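From compound 1 to compound 3: an ester replaces a ring

The compounds below may be only part of what the source reports. "The series", "measured", "known", "first", "only" and "open" are said of these compounds alone.

Compound 1 `CCn1nnc(-c2ccc(NC(=O)CSc3nnc(CNc4ccccc4)n3CC)cc2)n1` was tested in an assay on isolated protein for inhibition of long-chain fatty acid transport protein 1 (Homo sapiens); on this read-out higher numbers stand for weaker inhibition and lower numbers for stronger inhibition. In this assay compound 1 gives only a limit, > 1000 nM, and no number. A second compound, compound 2 `CC/C(=N/OC)c1ccc2oc(CSc3nnc(CNc4ccccc4)n3CC)nc2c1`, shares the thioether-linked core with an aniline-bearing side chain. In this assay compound 2 likewise gives only a limit, > 1000 nM. Compound 1 therefore stands at the edge of what the assay reports: the limit of > 1000 nM in this assay, at which 2 of the 2 values shown sit. Compound 3 `CCn1c(CNc2ccccc2)nnc1SCC(=O)Nc1ccc(C(=O)OC(C)(C)C)cc1` has not yet been measured in this assay. It differs from compound 1 in one place, (tert-butoxycarbonyl in place of 2-ethyl-2H-tetrazol-5-yl on an aromatic carbon), the new group sitting on an aromatic carbon of a six-membered aromatic ring of carbon only, para to a large group. Among the measured compounds shown here, no step between two measured compounds exists here to guide the size of the change. The author's expectation is that the step from compound 1 to compound 3, a step that the limit leaves unreadable from compound 1 to compound 3, stays within the usual scatter or leaves the compound still at the limit. Compound 3 is expected to reach about 3000 nM in this assay, within a range from 800 nM to 20000 nM.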

Compound 3, half-maximal inhibitory concentration: > 1000 nM
Compound 3 ended at the assay's limit; the forecaster's own chance of this, stated with the estimate: 65%; the middle value does not contradict the limit.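

Compound 1 and compound 3 both give only a limit in this assay, and the step between them cannot be read. The compounds shown leave open whether tert-butoxycarbonyl and 2-ethyl-2H-tetrazol-5-yl differ at all in this read-out, and what inhibition any of them reaches, since all rest at one limit: the limit of > 1000 nM in this assay, at which 3 of the 3 values shown sit.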